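A Methoxy Group Added to an Anilino Quinone

The compounds below may be only part of what the source reports. "The series", "measured", "known", "first", "only" and "open" are said of these compounds alone.

Compound 1 `O=C1C=C(Nc2ccccc2)C(=O)c2c1nc1n2[C@H]2OC[C@@H](O)[C@H]2OC1` is the reference point here. Among the measured compounds shown here, in a functional assay on ECa-109 cells for inhibition, with ECa-109 cell line (Homo sapiens) as the target, read by sulforhodamine B assay (a higher number here means a weaker inhibitor, a lower number a stronger inhibitor), compound 1 gives 4970 nM, the one full number available in this set. Compound 2 `CCCN(CCC)C1=CC(=O)c2c(nc3n2[C@H]2OC[C@@H](O)[C@H]2OC3)C1=O` carries a dipropylamino group where compound 1 has the anilino group. For compound 2 in this assay only a limit is known, > 16000 nM, so it is not placed by a number (the limit of > 16000 nM in this assay, at which 1 of the 2 values shown sits). Compound 3 `COc1ccccc1NC1=CC(=O)c2nc3n(c2C1=O)[C@H]1OC[C@@H](O)[C@H]1OC3` has not been measured. It differs from compound 1 in a single place: methoxy in place of hydrogen on an aromatic carbon. For the measured compounds named here, no step between two measured compounds is known, so the size of this change can only be expected, not read off. A change of this kind is expected to shift this assay little, no further than the usual scatter in either direction. Compound 3 is therefore expected to give about 4500 nM, within 1500 nM to 13000 nM. The step of a 1.1-fold lower number from compound 1 to compound 3 (0.04 log units; within the scatter) is expected to stay small.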

Compound 3, half-maximal inhibitory concentration: > 4000 nM
Compound 3: a limit, no number; the forecaster's own chance of this, stated with the estimate: 12%; the middle value lies beyond the limit too.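

In this assay compound 3 gives only a limit, > 4000 nM, and not a number. Among the compounds shown here, no step from compound 1 to compound 3 can therefore be read. The compounds shown leave open how large a change, and in which direction, methoxy in place of hydrogen brings in this assay.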